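From a fluorophenyl to a thiophene on the hydrazone carbon

This account rests on a few compounds, and the source may have more. Where it says the series, first, only, none or still open, it means among the compounds named here.

Within the data shown here, compound 1 `O=C(CSc1nnc(-c2ccncc2)o1)N/N=C/c1cccc(F)c1` gives 26700 nM in a functional assay on SW 1116 cells (Homo sapiens) for cytotoxicity, read by MTT assay, with a stated time of 48 h (on this read-out higher numbers stand for weaker inhibition and lower numbers for stronger inhibition), the highest of the three numbers measured so far. Compound 2 `O=C(CSc1nnc(-c2ccncc2)o1)N/N=C/c1ccc(O)c(O)c1` gives 1540 nM in this assay, and compound 3 `COc1cc(/C=N/NC(=O)CSc2nnc(-c3ccncc3)o2)ccc1O` gives 3590 nM. Both steps away from compound 1 are beyond the scatter: a 17-fold lower number from compound 1 to compound 2 (1.24 log units; beyond the scatter) and a 7.4-fold lower number from compound 1 to compound 3 (0.87 log units; beyond the scatter); between the two hydroxylated analogues, a 2.3-fold higher number from compound 2 to compound 3 (0.37 log units; beyond the scatter). Compound 4 `O=C(CSc1nnc(-c2ccncc2)o1)N/N=C/c1cccs1` has not yet been measured. It differs from compound 1 in one place: thiophen-2-yl in place of 3-fluorophenyl on a carbon with a double bond to nitrogen. Neither measured step bears directly on this change, since each of them brings a hydroxyl onto the aromatic ring, which the thiophen-2-yl group does not carry. What the measured steps do show is that the group on this carbon can move the number widely, as a 17-fold lower number from compound 1 to compound 2 (1.24 log units; beyond the scatter) makes plain. With no hydroxyl entering, the step from compound 1 is not expected to reach beyond the scatter, and for compound 4 it is estimated as a 1.3-fold lower number from compound 1 to compound 4 (0.13 log units; within the scatter). The estimate for compound 4 is 20000 nM, between 7000 nM and 55000 nM.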

Compound 4, half-maximal inhibitory concentration: 24900 nM
Compound 4: the middle estimate sits 1.2-fold (0.10 log units) below what was measured; measured number inside the range.
By their numbers in this assay, from the lowest: compound 2; then compound 3; then compounds 4 and 1 (each within the scatter of the next).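

In this assay, the change from 3-fluorophenyl to thiophen-2-yl on the carbon with a double bond to nitrogen gives a 1.1-fold lower number from compound 1 to compound 4 (0.03 log units; within the scatter) and so shows no readable difference, even though a six-membered aromatic ring of carbon only gives way to a five-membered aromatic ring with a hetero atom. The hydroxylated groups stand apart from thiophen-2-yl, with a 6.9-fold higher number from compound 3 to compound 4 (0.84 log units; beyond the scatter) for 4-hydroxy-3-methoxyphenyl and a 16-fold higher number from compound 2 to compound 4 (1.21 log units; beyond the scatter) for 3,4-dihydroxyphenyl, so among these four compounds the lower numbers occur only where the aromatic ring carries a hydroxyl, and none goes against this. Nothing available explains these differences.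

The compounds shown leave open whether a single hydroxyl on the phenyl ring would be enough to give such a step. They also leave open whether an amine or a carboxylic acid on that ring would do the same.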